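Ester to Amide on the Ethenyl Arm

The source may report more compounds than this note shows. Statements on the series, on what has been measured and on what is new or still open speak of the compounds shown alone.

Measured compounds:
compound 1, `CCOC(=O)/C=C/c1ccncc1-c1ccc2[nH]ccc2c1`, 100%
compound 2, `CCOC(=O)/C=C/c1ccncc1-c1ccc2c(ccn2C)c1`, 100%

Compound 1 `CCOC(=O)/C=C/c1ccncc1-c1ccc2[nH]ccc2c1` was tested in an assay on a protein complex for inhibition of CDK8/Cyclin C (Homo sapiens), with a stated time of 1 h, tested at 10 uM (a lower number here means less inhibition, a higher number more inhibition at the concentration tested (going by the name of the read-out)), and gave 100%. Compound 2 `CCOC(=O)/C=C/c1ccncc1-c1ccc2c(ccn2C)c1`, which carries a methyl in place of hydrogen on an aromatic nitrogen, gave 100% in this assay. The step of no change at the digits printed from compound 1 to compound 2 (within the scatter) shows that compound 1 stands level with compound 2 in the inhibition number at the concentration tested.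

Compound 3 `CNC(=O)/C=C/c1ccncc1-c1ccc2[nH]ccc2c1` has not been measured. It differs from compound 1 by methylamino in place of ethoxy on a carbonyl carbon. Among the compounds with values here, no measured step touches this part of the molecule: the only step recorded, no change at the digits printed from compound 1 to compound 2 (within the scatter), concerns the aromatic nitrogen and not the carbonyl carbon, so it gives no guide to the size of the present change. Because compound 1 gives 100%, there is no room for a higher number, and any change can only appear as a lower one. Compound 3 is expected to give a number in this assay close to that of compound 1, with an estimated value of 90% (range 60% to 100%), meaning an expected step of a number 10 percentage points lower from compound 1 to compound 3 (within the scatter).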

Compound 3, a percentage reported as inhibition, at one concentration (the size of the read-out at that concentration, not a potency): 100%
The estimate for compound 3 lay 10 percentage points below the measured number; the range from low to high includes it.
By their numbers in this assay, from the lowest: compounds 1, 2 and 3 (each within the scatter of the next).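

The change from ethoxy to methylamino on the carbonyl carbon, which turns the 2-(ethoxycarbonyl)ethenyl arm into 2-(methylcarbamoyl)ethenyl, gives no change at the digits printed from compound 1 to compound 3 (within the scatter) in this assay. This carbonyl carbon is a second place on the molecule, apart from the aromatic nitrogen of the earlier step, where a change leaves the printed number as it was, and the ester is thus not needed for this level of inhibition at the concentration tested. Nothing given here bears on why the number holds across this change.

On these data alone, all three compounds print the same number at a single concentration, so this assay cannot separate them, and any difference in potency between the ester and the amide stays open. Also open, as far as these compounds go, is how the arm fares with a carboxylic acid, a dimethylamino group or a longer chain on the amide nitrogen in place of methylamino, and whether the amide keeps its number when a methyl stands in place of hydrogen on the aromatic nitrogen.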